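Chloro on the benzyl ring of compound 2

The compounds below may be only part of what the source reports. "The series", "measured", "known", "first", "only" and "open" are said of these compounds alone.

The compounds share one core, varied at the amide on one end. Compound 1 `O=C(CSc1nc2ccc(NC(=O)c3ccc([N+](=O)[O-])cc3)cc2s1)NCc1ccccc1` returns only a limit in a functional assay on MCF7 cells (Homo sapiens) for cytotoxicity, read by MTT assay, with a stated time of 48 h (on this read-out lower numbers stand for stronger inhibition and higher numbers for weaker inhibition), > 100000 nM; this value is the limit (the limit of > 100000 nM in this assay, at which 1 of the 3 values shown sits). Compound 2 `CC(=O)Nc1ccc2nc(SCC(=O)NCc3ccccc3)sc2c1` gives 17600 nM in this assay, and compound 3 `O=C(CSc1nc2ccc(NC(=O)c3ccccc3)cc2s1)NCc1ccccc1` gives 35600 nM. Compound 2 stands lowest of the two numbers measured; its nearest neighbour is compound 3, with a 2.0-fold higher number from compound 2 to compound 3 (0.31 log units; beyond the scatter). The remaining steps, an at least 5.6-fold lower number from compound 1 to compound 2 (0.75 log units; beyond the scatter) and an at least 2.8-fold lower number from compound 1 to compound 3 (0.44 log units; beyond the scatter), concern that same amide end of the core.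

Compound 4 `CC(=O)Nc1ccc2nc(SCC(=O)NCc3ccc(Cl)cc3)sc2c1` is not yet measured. (chloro in place of hydrogen on an aromatic carbon). Among the compounds with values here, none of the measured steps touches the benzyl group, so no measured step bears directly on this change, and there is no precedent for substitution at this position. The step is therefore expected to stay within the scatter: a 1.2-fold lower number from compound 2 to compound 4 (0.07 log units; within the scatter). Compound 4 is estimated at 15000 nM, with a range from 5000 nM to 45000 nM.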

Compound 4, half-maximal inhibitory concentration: 10200 nM
Compound 4: middle estimate off by 1.5-fold (0.17 log units), on the high side; low and high end bracket the measured number.
By their numbers in this assay, from the lowest: compounds 4 and 2 (each within the scatter of the next); then compound 3. At a limit, above all of these: compound 1.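

The earlier steps shown here all concern the amide end of the core, whereas this pair varies the benzyl group, and in this assay chloro in place of hydrogen gives a 1.7-fold lower number from compound 2 to compound 4 (0.24 log units; within the scatter). A chloro on the benzyl ring, para to a large group, therefore leaves compound 2 and compound 4 indistinguishable in this read-out, so this change shows no effect that can be separated from the scatter. Nothing in the data shown bears on the size of this step.

Still open, on these data alone, is whether other groups at this place, such as methoxy, an amine or a carboxylic acid, would give a step beyond the scatter. Also open, as far as these compounds go, is whether the chloro change would give a similar step on compound 3, which carries phenyl in place of methyl at the amide end.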